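Shrinking an Acetylmorpholine Ring to an Acetylazetidine

The source may report more compounds than this note shows. Statements on the series, on what has been measured and on what is new or still open speak of the compounds shown alone.

Compound 3 `CC(=O)N1CCOC(CNC(=O)c2ccncc2Nc2cc(-c3ccc4ccn(C)c4c3)c3nccnc3c2)C1` was tested in an assay on lysate for inhibition of 6-phosphofructo-2-kinase/fructose-2,6-bisphosphatase 3 (Homo sapiens), with stated times of 0.5 min and 45 min; on this read-out higher numbers stand for weaker inhibition and lower numbers for stronger inhibition. In this assay compound 3 reaches only the limit > 100000 nM, so no number is known for it. Compound 1 `CN(C)C(=O)c1ccncc1Nc1cc(-c2ccc3ccn(C)c3c2)c2nccnc2c1` likewise gives only the limit > 100000 nM. Compound 2 `Cn1ccc2ccc(-c3cc(Nc4cnccc4C(=O)NCC4COCCN4)cc4nccnc34)cc21` gives 41700 nM. Two of the three values rest at the limit of > 100000 nM in this assay, at which 2 of the 3 values shown sit, so the step of an at least 2.3-fold higher number from compound 2 to compound 3 (0.37 log units; beyond the scatter) is readable only as a minimum, and a step that the two limits leave unreadable from compound 1 to compound 3 cannot be sized at all. Compound 4 `CC(=O)N1CC(CNC(=O)c2ccncc2Nc2cc(-c3ccc4ccn(C)c4c3)c3nccnc3c2)C1` differs from compound 3 by 1-acetylazetidin-3-yl in place of 4-acetylmorpholin-2-yl on a saturated chain carbon bound to an amide-type nitrogen. For the measured compounds named here, no measured step repeats this change, and the related step of an at least 2.3-fold higher number from compound 2 to compound 3 (0.37 log units; beyond the scatter) shows that altering the ring at this place can matter. Compound 4 is therefore expected near 100000 nM, between 30000 nM and 300000 nM, an expected step of a number no higher from compound 3 to compound 4 (the limit leaves the size open).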

Compound 4, half-maximal inhibitory concentration: > 100000 nM
Compound 4: no number, only a limit; the forecaster's own chance of this, stated with the estimate: 60%; the middle value lies on the limit itself.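

Replacing 4-acetylmorpholin-2-yl with 1-acetylazetidin-3-yl leaves compound 4 at a limit, so a second acetylated ring at this place gives no number in this assay. For the compounds shown here, the one readable comparison is an at least 2.3-fold higher number from compound 2 to compound 4 (0.37 log units; beyond the scatter). The other steps ending at compound 4 cannot be read, because both of their values are limits: the limit of > 100000 nM in this assay, at which 3 of the 4 values shown sit.

On these data alone, how far compound 3 and compound 4 lie apart stays open. Also open, as far as these compounds go, is what an azetidin-3-yl without the acetyl, or an amine on a longer chain, would give at this place.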